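Compound 3 to compound 4: a step behind a limit

This account rests on a few compounds, and the source may have more. Where it says the series, first, only, none or still open, it means among the compounds named here.

In a functional assay on L1210 cells (Mus musculus) for inhibition, with a stated time of 48 h (on this read-out higher numbers stand for weaker inhibition and lower numbers for stronger inhibition), compound 3 (`CCCNCCCCNCCCNCCC`) gives > 100000 nM, which is a limit of the assay and not a number. Compound 1 (`CCCNCCCNCCCNCCC`) gives > 100000 nM, also a limit. Compound 2 (`CCCNCCCNCCCCN`) gives > 100000 nM, again a limit. Compound 3 therefore has no readable rank among the three, and the evidence so far is the limit of > 100000 nM in this assay, at which 3 of the 3 values shown sit.

Compound 4 (`CCCNCCCCCNCCCCNCCC`) has not yet been measured. It carries 2-(propylamino)ethyl in place of propylamino on a saturated chain carbon, three bonds along the chain from an amine nitrogen.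

Within the data shown here, the nearest precedent is the swap of propylamino for (propylamino)methyl, which is a step that the two limits leave unreadable from compound 1 to compound 3. The other two steps, a step that the two limits leave unreadable from compound 1 to compound 2 and a step that the two limits leave unreadable from compound 2 to compound 3, give no size either. With no measured size to carry over, no step beyond the scatter is expected in either direction, and another limit is the likeliest result. The expected change is a number no higher from compound 3 to compound 4 (the limit leaves the size open). For compound 4 the estimated value is 100000 nM, with an expected range from 30000 nM to 300000 nM.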

Compound 4, half-maximal inhibitory concentration: 100000 nM
The estimate for compound 4 equals the measured number at the digits printed; low and high end bracket the measured number.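

In this assay, placing 2-(propylamino)ethyl on a saturated chain carbon, three bonds along the chain from an amine nitrogen, gives a number no higher from compound 3 to compound 4 (the limit leaves the size open). Among these compounds, compound 4, at 100000 nM, is the first compound here to give an actual number, so this place on the chain tolerates the larger group with the read-out still a number. Even so, the series remains close to that ceiling: the limit of > 100000 nM in this assay, at which 3 of the 4 values shown sit.

The steps among compound 1, compound 2 and compound 3 cannot be read, so the data give no size for any of these chain changes. Going by these compounds, whether a longer chain than 2-(propylamino)ethyl, or a carboxylic acid in its place, would lower the number further stays open.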